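A Second Fluorine on the Aryl Ring of Compound 3

The compounds below may be only part of what the source reports. "The series", "measured", "known", "first", "only" and "open" are said of these compounds alone.

Of the compounds shown here, three sharing one core have been measured in an assay on cells for inhibition of histone deacetylase 4 (Homo sapiens), read by fluorescence, with a stated time of 30 min; a lower number here means a stronger inhibitor, a higher number a weaker inhibitor. Compound 1 `O=C1NC(=O)/C(=C\c2ccc(OCC(=O)N3N=C(c4ccccc4)CC3c3ccc(F)cc3F)cc2)S1` gives 2200 nM. Compound 2 `O=C1NC(=O)/C(=C\c2ccc(OCC(=O)N3N=C(c4ccc(F)cc4)CC3c3ccco3)cc2)S1` gives 880 nM in this assay. Compound 3 `O=C1NC(=O)/C(=C\c2ccc(OCC(=O)N3N=C(c4ccc(F)cc4)CC3c3ccc(F)cc3)cc2)S1` gives 1400 nM. Compound 3 thus stands second highest of the three numbers; its nearest neighbour is compound 1 and its furthest is compound 2, and both gaps lie within the scatter. Among the compounds with values here, the only single-point step among the measured compounds is a 1.6-fold higher number from compound 2 to compound 3 (0.20 log units; within the scatter), itself within the scatter.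

Compound 4 `O=C1NC(=O)/C(=C\c2ccc(OCC(=O)N3N=C(c4ccc(F)cc4)CC3c3ccc(F)cc3F)cc2)S1` differs from compound 3 by fluoro in place of hydrogen on an aromatic carbon. Within the data shown here, no measured step addresses this particular change. Compound 1, which carries a 2,4-difluorophenyl group on the saturated ring carbon, differs from compound 3 in two places, so its value and that of compound 3 can only be set side by side, and they lie within the scatter of each other. On this basis no step beyond the scatter is expected when moving from compound 3 to its fluorinated analogue. The expected step in this assay is a 1.1-fold higher number from compound 3 to compound 4 (0.06 log units; within the scatter). Compound 4 is therefore estimated at 1600 nM in this assay, with a range from 700 nM to 3500 nM.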

Compound 4, half-maximal inhibitory concentration: 1600 nM
The estimate for compound 4 equals the measured number at the digits printed; measured number inside the range.
By their numbers in this assay, from the lowest: compounds 2, 3, 4 and 1 (each within the scatter of the next, the first and the last beyond it).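

In this assay, within the data shown here, the change from 4-fluorophenyl to 2,4-difluorophenyl (a 1.1-fold higher number from compound 3 to compound 4 (0.06 log units; within the scatter)) gives the first reading at this position, and fluoro in place of hydrogen on this aromatic carbon, ortho to a large group and meta to a fluoro group, stays within the scatter. The same kind of replacement at a different aromatic carbon, which links compound 1 and compound 4 (a 1.4-fold lower number from compound 1 to compound 4 (0.14 log units; within the scatter)), also stays within the scatter, so neither fluoro replacement shown here moves the number beyond it. Exchanging furan-2-yl for 2,4-difluorophenyl on the saturated ring carbon (a 1.8-fold higher number from compound 2 to compound 4 (0.26 log units; within the scatter)) likewise stays within the scatter, as does the exchange for 4-fluorophenyl (a 1.6-fold higher number from compound 2 to compound 3 (0.20 log units; within the scatter)).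

The compounds shown leave open whether a group other than fluoro on this aromatic carbon, such as chloro, methoxy, an amine or a carboxylic acid, would give a step beyond the scatter. Nothing further is available to account for the size of these steps.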